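The source may report more compounds than this note shows. Statements on the series, on what has been measured and on what is new or still open speak of the compounds shown alone.

Measured so far:
- compound 1 `CCCCCCCCO[C@H]1O[C@@H]2COC(=O)CCCCCCC(=O)O[C@H]2[C@H](O)[C@H]1O`: 38100 nM
- compound 2 `CCCCCCCCO[C@H]1O[C@@H]2COC(c3ccccc3)O[C@H]2[C@H](O)[C@H]1O`: 47100 nM

Both values come from a functional assay on BT-20 cells (Homo sapiens) for antiproliferative activity, read by MTT assay, with a stated time of 48 h; on this read-out lower numbers stand for stronger inhibition and higher numbers for weaker inhibition. Compound 2, at 47100 nM, lies within the scatter of compound 1, so the two cannot be ranked. Within the data shown here, no measured pair differs in one place only, which leaves the series without a direct guide to the size of a single change.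

Compound 3 `CCCCCCCCO[C@@H]1O[C@@H]2COC(c3ccccc3)O[C@H]2[C@H](O)[C@H]1O` has not yet been measured. The change to it is this: the two compounds have the same atoms and bonds; at least one stereo element is drawn with a configuration in one of them and without one in the other: 1 of 6 stereo elements differ; a stereocentre at a saturated ring carbon is drawn S in compound 2 and R in compound 3. The two compounds have the same atoms and bonds, and a stereocentre at a saturated ring carbon is drawn S in compound 2 and R in compound 3.

No shift beyond the scatter is expected, in either direction, and this expectation rests on compound 2 at 47100 nM. The expected size is a 1.1-fold lower number from compound 2 to compound 3 (0.05 log units; within the scatter). For compound 3 the estimated value is 42000 nM, with an expected range of 18000 nM to 95000 nM.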

Compound 3, half-maximal inhibitory concentration: 72100 nM
The estimate for compound 3 lay 1.7-fold (0.23 log units) below the measured number; the measured number falls inside the stated range.
By their numbers in this assay, from the lowest: compounds 1, 2 and 3 (each within the scatter of the next).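

Among these compounds, this is the first step that alters one place only, with atoms and bonds unchanged: a stereocentre at a saturated ring carbon is drawn S in compound 2 and R in compound 3. In this assay the step is a 1.5-fold higher number from compound 2 to compound 3 (0.18 log units; within the scatter), so the configuration at this position produces no difference beyond the scatter in this pair. The comparison carries one caveat: the fact that one of compounds 2 and 3 is drawn with a defined configuration and the other without, at the place where they differ

The compounds shown leave open whether the two configurations stay within the scatter of each other once a longer chain or an amine is carried on the shared core. They also leave open how the same stereocentre reads out on the core of compound 1.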